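The source may report more compounds than this note shows. Statements on the series, on what has been measured and on what is new or still open speak of the compounds shown alone.

In a functional assay on MCF7 cells (Homo sapiens) for antiproliferative activity, read by sulforhodamine B assay, with a stated time of 48 h (a lower number here means a stronger inhibitor, a higher number a weaker inhibitor), compound 3 `CCCCCN(C)C(=O)CCCCCOc1cc(OC)c(OC)c2oc(-c3ccc(OC)cc3)c(O)c(=O)c12` gives 34900 nM, and compound 1 `CCCCN(C)C(=O)CCCCOc1cc(OC)c(OC)c2oc(-c3ccc(OC)cc3)c(O)c(=O)c12` gives 22300 nM; these two values lie within the scatter of each other. Compound 2 `COc1ccc(-c2oc3c(OC)c(OC)cc(OCCCCC(=O)NCc4ccccn4)c3c(=O)c2O)cc1` reads > 40000 nM, which is a limit of the assay and not a number.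

Compound 4 `COc1ccc(-c2oc3c(OC)c(OC)cc(OCCCCCC(=O)N4CCN(C)CC4)c3c(=O)c2O)cc1` is the next analogue to follow from compound 3: 4-methylpiperazin-1-yl in place of methyl(pentyl)amino on a carbonyl carbon. The chain and the shared core stay the same, and 4-methylpiperazin-1-yl replaces methyl(pentyl)amino on a carbonyl carbon.

The measured steps that bear on this change are those that alter the amide group: an at least 1.7-fold higher number from compound 1 to compound 2 (0.25 log units; that floor lies within the scatter), a 1.6-fold higher number from compound 1 to compound 3 (0.19 log units; within the scatter) and an at least 1.1-fold lower number from compound 2 to compound 3 (0.05 log units; that floor lies within the scatter). None of them exceeds the scatter, although the first and third rest on a limit. Going by the values given here, compound 2, with an at least 1.1-fold lower number from compound 2 to compound 3 (0.05 log units; that floor lies within the scatter), is the only measured compound with a ring in that group.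

No step beyond the scatter is therefore expected in this assay, and the expected step is a 1.1-fold lower number from compound 3 to compound 4 (0.04 log units; within the scatter). A result reported only as a limit is also plausible, given (the limit of > 40000 nM in this assay, at which 1 of the 3 values shown sits). Compound 4 is estimated at 32000 nM, with an expected range of 14000 nM to 70000 nM.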

Compound 4, half-maximal inhibitory concentration: 14100 nM
Beside the measured number, compound 4's estimate is 2.3-fold (0.36 log units) above it; low and high end bracket the measured number.
By their numbers in this assay, from the lowest: compounds 4, 1 and 3 (each within the scatter of the next, the first and the last beyond it). At a limit, above all of these: compound 2.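

In this assay, a change on the carbonyl carbon now gives a step beyond the scatter between two measured numbers: a 2.5-fold lower number from compound 3 to compound 4 (0.39 log units; beyond the scatter), and the same holds for the floor of an at least 2.8-fold lower number from compound 2 to compound 4 (0.45 log units; beyond the scatter). Compound 2 stands at a limit and not a number, and it also carries a ring in this group, so a ring alone does not go with the lower number: the limit of > 40000 nM in this assay, at which 1 of the 4 values shown sits. The pattern does not extend to every amide, as compound 1 goes against it: a 1.6-fold lower number from compound 1 to compound 4 (0.20 log units; within the scatter).

Still open, going by these compounds, is whether the step follows the ring or its second nitrogen; a piperidine or morpholine amide on the same chain would separate the two. Also open, on these data alone, is whether 4-methylpiperazin-1-yl gives a similar step on a shorter chain.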